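The source may report more compounds than this note shows. Statements on the series, on what has been measured and on what is new or still open speak of the compounds shown alone.

Measured in a functional assay (aorta) with Rattus norvegicus as the target; on this read-out higher numbers stand for weaker inhibition and lower numbers for stronger inhibition:
- compound 1 `COc1ccc(CN(C)CCCCOc2ccc(S(=O)(=O)c3c(C(C)C)cn4ccccc34)cc2)cc1OC`: 14.6 nM
- compound 2 `CC(C)c1cn2ccccc2c1S(=O)(=O)c1ccc(OCCCNCc2ccccc2)cc1`: 22.8 nM
- compound 3 `CCCCc1cn2ccccc2c1S(=O)(=O)c1ccc(OCCCN(CCCC)CCCC)cc1`: 284 nM

Compound 2, at 22.8 nM, lies within the scatter of compound 1, while compound 3 stands clearly higher at 284 nM. Compound 4 `CCN(CC)CCCOc1ccc(S(=O)(=O)c2c(C(C)C)cn3ccccc23)cc1` is reached from compound 2 by diethylamino in place of benzylamino on a saturated chain carbon, three bonds along the chain from an oxygen on an aromatic ring, with diethylamino in place of benzylamino. Among the compounds with values here, no measured pair isolates this change. Compound 3, at 284 nM, has no aromatic ring on its amine side, but it also differs elsewhere, so it supports only a modest expected rise in number, meaning weaker inhibition. The expected step is a 2.6-fold higher number from compound 2 to compound 4 (0.42 log units; beyond the scatter). For compound 4 the estimated value is 60 nM, with a range of 18 nM to 200 nM.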

Compound 4, half-maximal inhibitory concentration: 228 nM
Compound 4: middle estimate off by 3.8-fold (0.58 log units), on the low side; measured number above the stated range.
By their numbers in this assay, from the lowest: compounds 1 and 2 (each within the scatter of the next); then compounds 4 and 3 (each within the scatter of the next).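

In this assay, within the data shown here, diethylamino in place of benzylamino on a saturated chain carbon, three bonds along the chain from an oxygen on an aromatic ring, gives a 10-fold higher number from compound 2 to compound 4 (1.00 log units; beyond the scatter) and is the first change at this position seen on its own. The position therefore responds to the amine group it carries, and the step is beyond the scatter.

On these data alone, the change removes an aromatic ring and a hydrogen-bond donor together, so it remains open which matters, and cyclohexylmethylamino or ethylamino at this position could separate them. Nothing available here gives a reason for the step.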